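This account rests on a few compounds, and the source may have more. Where it says the series, first, only, none or still open, it means among the compounds named here.

Measured compounds:
compound 1, `COc1ccc(NC(=S)NC(=O)Nc2ccc3c(c2)C(=O)C(=O)N3Cc2ccccc2)cc1`: 2.39
compound 2, `O=C(NC(=S)Nc1ccccc1Cl)Nc1ccc2c(c1)C(=O)C(=O)N2Cc1ccccc1Cl`: 3.98

In a physicochemical assay for lipophilicity, in phosphate buffer, measured as octanol-water partition (on this read-out lower numbers stand for lower lipophilicity and higher numbers for higher lipophilicity), compound 1 gives 2.39, the lower of the two numbers in hand. Among the compounds with values here, compound 2, the only other measured member, gives 3.98 in this assay, and the gap between the two lies beyond the scatter of repeated measurements. The two compounds differ in more than one place, so no single step can be read from that gap.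

Compound 3, `COc1ccc(NC(=S)NC(=O)Nc2ccc3c(c2)C(=O)C(=O)N3Cc2ccccc2Cl)cc1`, is the next member to be measured in this assay. Compared with compound 1 it carries the change (chloro in place of hydrogen on an aromatic carbon), that is, chloro in place of hydrogen on an aromatic carbon. Within the data shown here, no measured pair isolates this change, so the size of the step rests on the change itself rather than on a precedent. The expectation is a moderate rise in this assay from compound 1, with a step of about a number 0.61 log units higher from compound 1 to compound 3 (beyond the scatter). On that basis compound 3 is estimated at 3 in this assay, within a range from 2.6 to 3.4.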

Compound 3, partition coefficient: 3.24
Compound 3: middle estimate off by 0.24 log units, on the low side; the measured number falls inside the stated range.
By their numbers in this assay, from the lowest: compound 1; then compound 3; then compound 2.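

In this assay the chloro group on an aromatic carbon, ortho to a large group, now has a step of its own: benzyl to 2-chlorobenzyl gives a number 0.85 log units higher from compound 1 to compound 3 (beyond the scatter) and so lies beyond the scatter. The same compound 3 also isolates the other end of the molecule, where 4-methoxyphenyl in place of 2-chlorophenyl on an amide-type nitrogen gives a number 0.74 log units lower from compound 2 to compound 3 (beyond the scatter) and also lies beyond the scatter, so the gap between compound 1 and compound 2, unreadable before, now resolves into two single changes with compound 3 between them. Nothing shown bears on why either step has this size.

Within the data shown here, the chloro step is seen only with 4-methoxyphenyl on the amide-type nitrogen, so whether it keeps its size with 2-chlorophenyl there remains open. Also open, on these data alone, is how this assay responds to a fluoro group, a methyl group, an amine or a carboxylic acid in the same place on the benzyl group.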